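The source may report more compounds than this note shows. Statements on the series, on what has been measured and on what is new or still open speak of the compounds shown alone.

Measured so far:
compound 1 `CC(=O)NS(=O)(=O)c1ccc(N/C(S)=N\c2ccnc3cc(C(F)(F)F)ccc23)cc1`: 28300 nM
compound 2 `O=S(=O)(Nc1nccs1)c1ccc(N/C(S)=N\c2ccnc3cc(C(F)(F)F)ccc23)cc1`: 27300 nM

In a functional assay on HT-1080 cells (Homo sapiens) for antiproliferative activity, read by sulforhodamine B assay, with a stated time of 48 h (on this read-out higher numbers stand for weaker inhibition and lower numbers for stronger inhibition), compound 1 gives 28300 nM and compound 2 gives 27300 nM. The step of a 1.0-fold lower number from compound 1 to compound 2 (0.02 log units; within the scatter) is within the scatter, so compound 2 and compound 1 cannot be told apart on this read-out; compound 2 stands together with compound 1 and nothing separates the two.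

Compound 3 `O=S(=O)(Nc1ncccn1)c1ccc(N/C(S)=N\c2ccnc3cc(C(F)(F)F)ccc23)cc1` is the next variation at the same position: pyrimidin-2-yl in place of 1,3-thiazol-2-yl on a sulfonamide nitrogen. Among the measured compounds shown here, the only measured step at the sulfonamide nitrogen is a 1.0-fold lower number from compound 1 to compound 2 (0.02 log units; within the scatter), which did not move the number beyond the scatter. For the measured compounds named here, no step with a six-membered ring at this position has been measured, so the expectation rests on that single step alone. Compound 3 is therefore expected to sit close to compound 2, with a 1.0-fold lower number from compound 2 to compound 3 (0.00 log units; within the scatter) expected to stay within the scatter. The estimate for compound 3 is 27000 nM, with a range from 12000 nM to 60000 nM.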

Compound 3, half-maximal inhibitory concentration: 29100 nM
Beside the measured number, compound 3's estimate is 1.1-fold (0.03 log units) below it; the range from low to high includes it.
By their numbers in this assay, from the lowest: compounds 2, 1 and 3 (each within the scatter of the next).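

In this assay, the six-membered pyrimidin-2-yl in place of the five-membered 1,3-thiazol-2-yl on a sulfonamide nitrogen gives a 1.1-fold higher number from compound 2 to compound 3 (0.03 log units; within the scatter), so this change of ring size does not separate the two compounds. Set against the acetyl group, pyrimidin-2-yl gives a 1.0-fold higher number from compound 1 to compound 3 (0.01 log units; within the scatter), which places acetyl and both aromatic rings together on this read-out at this position. No measurement is available to account for this lack of separation.

On these data alone, whether a methyl group, a longer alkyl chain or a chain ending in an amine or a carboxylic acid on this nitrogen would stand apart from these three remains open. Also open, as far as these compounds go, is whether the numbers would respond to a change elsewhere on the shared core, such as chlorine in place of trifluoromethyl.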